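Heteroaryl acyloxymethyl ester variation on the phosphate series

The source may hold more compounds than are shown below. What is called first, only, known or untested is meant among the compounds shown, and "the series" means these compounds.

Compound 2 `COC(=O)CCNC(=O)[C@@H]1O[P@@](=O)(OCOC(=O)c2cc(C(C)(C)C)n[nH]2)OCC1(C)C` stands at the ceiling of an ADME assay on blood (Homo sapiens) for pharmacokinetics; a lower number here means that the compound disappears faster, a higher number that the compound lasts longer: in this assay compound 2 gives > 1 h, which is a limit and not a number, the one at the limit of > 1 h in this assay, at which 1 of the 3 values shown sits. Compound 1 `COC(=O)CCNC(=O)[C@@H]1O[P@@](=O)(OCOC(=O)c2ocnc2C)OCC1(C)C` gives 0.52 h. Compound 3 `CC(C)(C)C(=O)OCO[P@@]1(=O)OCC(C)(C)[C@H](C(=O)NCCC(=O)OCCS(C)(=O)=O)O1` gives < 0.16 h, also a limit, the one at the limit of < 0.16 h in this assay, at which 1 of the 3 values shown sits. Compound 4 `COC(=O)CCNC(=O)[C@@H]1O[P@@](=O)(OCOC(=O)c2scnc2C)OCC1(C)C` is not yet measured. The change 4-methyl-1,3-thiazol-5-yl in place of 3-(tert-butyl)-1H-pyrazol-5-yl on a carbonyl carbon removes the group that the step of an at least 1.9-fold higher number from compound 1 to compound 2 (0.28 log units; that floor lies within the scatter) brought in, so that step bears on it in reverse; its floor lies within the scatter, so only a modest move downward can be counted on. The expected step is an at least 1.6-fold lower number from compound 2 to compound 4 (0.22 log units; that floor lies within the scatter), back toward the value of compound 1. Compound 4 is estimated at 0.6 h, with a range from 0.3 h to 1.2 h.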

Compound 4, half-life: > 1 h
Compound 4: only a limit was reported; the forecaster's own chance of this, stated with the estimate: 20%; middle value at least 1.6-fold (0.22 log units) away from the limit.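

The 3-(tert-butyl)-1H-pyrazol-5-yl group is not alone in reaching the upper limit on this carbonyl carbon, since the smaller 4-methyl-1,3-thiazol-5-yl group reaches it too. 4-Methyl-1,3-thiazol-5-yl in place of 4-methyl-1,3-oxazol-5-yl gives an at least 1.9-fold higher number from compound 1 to compound 4 (0.28 log units; that floor lies within the scatter). Compound 2 and compound 4 both stand at a limit in this assay, so the step between them cannot be read: the limit of > 1 h in this assay, at which 2 of the 4 values shown sit.

Going by these compounds, how long either compound lasts beyond that limit remains open. So does whether an amine or a carboxylic acid on this heteroaryl ring would keep the half-life at that limit.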